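A Difluoromethyl Cap on an Aromatic Nitrogen

This account rests on a few compounds, and the source may have more. Where it says the series, first, only, none or still open, it means among the compounds named here.

Of the compounds shown here, three sharing one core have been tested in an assay on isolated protein for inhibition of tyrosine-protein kinase receptor UFO (Homo sapiens), read by LC-MS; on this read-out higher numbers stand for weaker inhibition and lower numbers for stronger inhibition. Compound 3 `Cc1cc(-c2c(C)n[nH]c2C)ccc1-c1nnc(N(C)Cc2ccc3nccn3c2)o1` gives 5010 nM, the highest number of the three, which on this read-out means the weakest inhibition. Compound 1 `COc1ccccc1-c1ccc(-c2nnc(N(C)Cc3ccc4nccn4c3)o2)cc1` gives 1580 nM and compound 2 `Cc1cc(-c2c(C)nn(C)c2C)cnc1-c1nnc(N(C)Cc2ccc3nccn3c2)o1` gives 1000 nM; both gaps to compound 3 lie beyond the usual scatter. Compound 4 `Cc1cc(-c2c(C)nn(C(F)F)c2C)ccc1-c1nnc(N(C)Cc2ccc3nccn3c2)o1` differs from compound 3 in one place: difluoromethyl in place of hydrogen on an aromatic nitrogen. Among the compounds with values here, no measured pair isolates this exact change, so its direction is uncertain. Compound 2 carries a methyl on an aromatic nitrogen of its own five-membered ring and shows a lower number, but it also differs from compound 3 elsewhere. A modest gain is expected, with the step of a 2.5-fold lower number from compound 3 to compound 4 (0.40 log units; beyond the scatter) estimated as small. Compound 4 is therefore estimated at 2000 nM, within 700 nM to 6000 nM.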

Compound 4, half-maximal inhibitory concentration: 63100 nM
For compound 4 the middle estimate is 32-fold (1.50 log units) below the measured one; the whole stated range lies below it.
By their numbers in this assay, from the lowest: compounds 2 and 1 (each within the scatter of the next); then compound 3; then compound 4.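

On this core, the aromatic nitrogen of the 3,5-dimethyl-1H-pyrazol-4-yl group is sensitive to what it carries: in this assay difluoromethyl in place of hydrogen gives a 13-fold higher number from compound 3 to compound 4 (1.10 log units; beyond the scatter) and so a clear weakening of inhibition. Within the data shown here, this is the first change at a single place that can be read, and it shows that this position can strongly affect inhibition. No measurement shown explains the loss. Going by these compounds, whether a smaller or larger group, such as an ethyl or a trifluoromethyl, would weaken inhibition as much on this nitrogen remains open. So does whether the same change would act alike on the core of compound 1.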